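Removing one chloro from compound 2

This account rests on a few compounds, and the source may have more. Where it says the series, first, only, none or still open, it means among the compounds named here.

Values in a functional assay on A549 cells (Homo sapiens) for antiproliferative activity, read by MTT assay, with a stated time of 72 h (a lower number here means a stronger inhibitor, a higher number a weaker inhibitor), stand as follows.
Compound 1 (`NC1=NC2(CCOCC2)N(OCCCOc2ccccc2)C(N)=N1`) gives 1080 nM
Compound 2 (`NC1=NC2(CCSCC2)N(OCCCOc2cccc(Cl)c2Cl)C(N)=N1`) gives 1 nM
Compound 3 (`NC1=NC2(CCOCC2)N(OCCCOc2ccccc2Br)C(N)=N1`) gives 160 nM

Of these three, compound 2 holds the lowest number (1 nM), far beneath both others. Compound 4 (`NC1=NC2(CCSCC2)N(OCCCOc2ccccc2Cl)C(N)=N1`) has not yet been measured and shares the core of compound 2. The two differ as 2,3-dichlorophenyl to 2-chlorophenyl, with hydrogen in place of chloro on an aromatic carbon.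

Within the data shown here, only one measured step bears on this change, and it does so indirectly. It is a 6.8-fold lower number from compound 1 to compound 3 (0.83 log units; beyond the scatter) and comes from a bromo in place of hydrogen on an aromatic carbon. That step involves another halogen and the core of compound 1, and it runs in the opposite sense, since here a halogen leaves. Among the measured compounds shown here, no measured pair shows the effect of this particular chloro, so the size of the step remains uncertain. Expected in this assay is therefore an 8.0-fold higher number from compound 2 to compound 4 (0.90 log units; beyond the scatter) and thus a rise of similar, modest size. The estimate for compound 4 is 8 nM (expected range 2 nM to 50 nM).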

Compound 4, half-maximal inhibitory concentration: 80 nM
The estimate for compound 4 lay 10-fold (1.00 log units) below the measured number; the measured number lies above the stated range.
By their numbers in this assay, from the lowest: compound 2; then compounds 4 and 3 (each within the scatter of the next); then compound 1.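

Replacing the chloro ortho to a chloro group with hydrogen, which turns 2,3-dichlorophenyl into 2-chlorophenyl, gives in this assay an 80-fold higher number from compound 2 to compound 4 (1.90 log units; beyond the scatter), so this one heavy atom at this place carries a large part of the activity of compound 2. Among these compounds, the only earlier step, a 6.8-fold lower number from compound 1 to compound 3 (0.83 log units; beyond the scatter), was modest and concerned a bromo entering on the core of compound 1, so it said nothing about this place on the aromatic ring or about the core shared by compound 2 and compound 4. Among the compounds shown here, this pair is the first to show that, on this shared core, the value depends strongly on this particular chloro, although nothing at hand gives any reason for the size of the step.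

The compounds shown leave open whether a fluoro, a methyl, a methoxy or an amine at this place would keep the low number of compound 2 or fall closer to the number of compound 4. They also leave open whether the same chloro would produce a step of similar size on the core of compound 1, and how a longer chain in place of the present one would change the picture.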